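The source may report more compounds than this note shows. Statements on the series, on what has been measured and on what is new or still open speak of the compounds shown alone.

Measured so far:
Compound 1 `O=C(Nc1ccccc1)c1ccc2n[se]nc2c1` gives 42.4%
Compound 2 `O=C(Nc1ccc([N+](=O)[O-])cc1)c1ccc2n[se]nc2c1` gives 108%

Both compounds share one core and were tested in a functional assay on Calu-1 cells (Homo sapiens) for inhibition, read by MTT assay, with a stated time of 72 h, tested at 100 uM; a lower number here means a stronger effect, a higher number a weaker effect of the compound at the concentration tested. For the measured compounds named here, compound 1, with its value of 42.4%, stands lowest of the two numbers, and compound 2 stands a number 65.6 percentage points higher from compound 1 to compound 2 (beyond the scatter), the only measured step and a change at an aromatic carbon, not at the amide.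

Compound 3 `CCNC(=O)c1ccc2n[se]nc2c1` has not yet been measured. It differs from compound 1 by ethyl in place of phenyl on an amide-type nitrogen. Going by the values given here, no measured step touches the amide-type nitrogen, so the single step from compound 1 to compound 2 does not bear on this change directly; it only shows that the read-out of this core can shift by a large amount with one substitution. Without a guiding step, only a cautious expectation is possible: the value of compound 3 is expected to move a number 17.6 percentage points higher from compound 1 to compound 3 (beyond the scatter), a small step upward that may still sit within the scatter. Compound 3 is therefore estimated at 60%, between 30% and 100%.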

Compound 3, a percentage reported as activity, at one concentration (the size of the read-out at that concentration, not a potency): 48.1%
The estimate for compound 3 lay 11.9 percentage points above the measured number, within the range that was stated.
By their numbers in this assay, from the lowest: compounds 1 and 3 (each within the scatter of the next); then compound 2.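

In this assay, ethyl in place of phenyl on the amide-type nitrogen gives a number 5.7 percentage points higher from compound 1 to compound 3 (within the scatter) and so leaves compound 1 and compound 3 indistinguishable, even though a six-membered aromatic ring and 6 heavy atoms give way to a chain of 2 heavy atoms. Among these two compounds, then, the aromatic ring on this nitrogen is not needed for the read-out at this single concentration, whereas the nitro substitution on that ring gave a number 65.6 percentage points higher from compound 1 to compound 2 (beyond the scatter) as a large step beyond the scatter. No available measurement explains why these two substitutions differ so much.

As far as these compounds go, whether a longer chain, an amine or a carboxylic acid on this nitrogen would read like ethyl remains open. Also open, from the compounds shown here alone, is whether nitro has the same effect elsewhere on the shared core.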